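The compounds below may be only part of what the source reports. "The series", "measured", "known", "first", "only" and "open" are said of these compounds alone.

Of the compounds shown here, three sharing one core have been measured so far. In a functional assay on HepG2 cells (Homo sapiens) for antiproliferative activity, read by MTT assay, with a stated time of 48 h (on this read-out higher numbers stand for weaker inhibition and lower numbers for stronger inhibition), compound 1 `C#CC(C)OC(=O)c1ccc(C(CC)(CC)c2ccc(OCCC(O)(CC)CC)c(C)c2)n1CC` gives > 50000 nM, which is a limit of the assay and not a number. Compound 2 `CCC(C)C(NC(=O)c1ccc(C(CC)(CC)c2ccc(OCCC(O)(CC)CC)c(C)c2)n1CC)C(=O)OC` likewise gives a limit, > 50000 nM. Compound 3 `CCOC(=O)C(CC(=O)OC)NC(=O)c1ccc(C(CC)(CC)c2ccc(OCCC(O)(CC)CC)c(C)c2)n1CC` also stands only at a limit, > 50000 nM. The whole series thus rests at the limit of > 50000 nM in this assay, at which 3 of the 3 values shown sit.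

Compound 4 `CCn1c(C(=O)NC(C)C(=O)O)ccc1C(CC)(CC)c1ccc(OCCC(O)(CC)CC)c(C)c1` differs from compound 3 in one place: a group of 5 heavy atoms (3 carbon, 2 oxygen; no ring) in place of a group of 11 heavy atoms (7 carbon, 4 oxygen; no ring), on an amide-type nitrogen. Here 1-carboxyethyl takes the place of the larger group on the amide-type nitrogen. The measured steps that bear on this are a step that the two limits leave unreadable from compound 1 to compound 2, a step that the two limits leave unreadable from compound 1 to compound 3 and a step that the two limits leave unreadable from compound 2 to compound 3, the last of them at that same nitrogen. For the measured compounds named here, none has a readable size, and no measured compound carries 1-carboxyethyl, so they fix neither a size nor a direction. The expected step, a number no higher from compound 3 to compound 4 (the limit leaves the size open), is therefore small and uncertain in direction. Compound 4 is estimated at 50000 nM, with an expected range of 15000 nM to 100000 nM, and it may well meet the same limit in this assay.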

Compound 4, half-maximal inhibitory concentration: 1740 nM
For compound 4 the middle estimate is 29-fold (1.46 log units) above the measured one, and the stated range ends above it.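

In this assay, for the compounds shown here, the group on the amide-type nitrogen proves able to move the read-out, which the earlier compounds could not show: 1-carboxyethyl gives an at least 28-fold lower number from compound 3 to compound 4 (1.45 log units; beyond the scatter) and an at least 28-fold lower number from compound 2 to compound 4 (1.45 log units; beyond the scatter). Seen from the carbonyl carbon, (1-carboxyethyl)amino in place of (1-methylprop-2-yn-1-yl)oxy gives an at least 28-fold lower number from compound 1 to compound 4 (1.45 log units; beyond the scatter). Compound 4 is the only compound shown that stands off the limit: the limit of > 50000 nM in this assay, at which 3 of the 4 values shown sit.

The compounds shown do not tell whether the step follows the carboxylic acid of 1-carboxyethyl or the shorter group as a whole, a question that the methyl ester or the primary amide of the same group would address. They also leave open whether a longer chain ending in a carboxylic acid, or an amine in place of that acid, would give a number of this order.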